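This account rests on a few compounds, and the source may have more. Where it says the series, first, only, none or still open, it means among the compounds named here.

Measured compounds in a functional assay on HepG2 cells (Homo sapiens) for inhibition, read by MTT assay, with a stated time of 72 h; a higher number here means a weaker inhibitor, a lower number a stronger inhibitor:

compound 1 `COc1ccc(-n2cc(COc3cccc(NC(=O)Nc4ccc(Cl)c(C(F)(F)F)c4)c3)nn2)cc1` gives 4680 nM
compound 2 `CC(C)c1ccc(-n2cc(COc3cccc(NC(=O)Nc4ccc(Cl)c(C(F)(F)F)c4)c3)nn2)cc1` gives 2470 nM
compound 3 `O=C(Nc1cccc(OCc2cn(-c3cccc(Cl)c3)nn2)c1)Nc1ccc(Cl)c(C(F)(F)F)c1` gives 2020 nM

All three share one core and differ only in the aromatic group carried on the aromatic nitrogen. On the numbers shown, compound 3 has the lowest value in this assay, which means the strongest inhibition of the three. Its nearest neighbour is compound 2, whose value lies within the scatter of repeated measurements, as a 1.2-fold lower number from compound 2 to compound 3 (0.09 log units; within the scatter) shows; the gap to compound 1 is larger, a 2.3-fold lower number from compound 1 to compound 3 (0.36 log units; beyond the scatter), a modest step beyond the scatter. Between compound 1 and compound 2 the step is a 1.9-fold lower number from compound 1 to compound 2 (0.28 log units; within the scatter).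

Compound 4 `O=C(Nc1cccc(OCc2cn(-c3cccc(Br)c3)nn2)c1)Nc1ccc(Cl)c(C(F)(F)F)c1` has not yet been tested. It differs from compound 3 by bromo in place of chloro on an aromatic carbon. Within the data shown here, no measured pair exchanges one halogen for another, so the only guidance is indirect: the larger swaps of whole aryl groups on this same nitrogen, seen in the three steps above, moved this assay at most modestly. An exchange confined to a single position is expected to do no more, and no step beyond the scatter is expected; the estimated step is a 1.1-fold lower number from compound 3 to compound 4 (0.05 log units; within the scatter). Compound 4 is therefore expected to give about 1800 nM, with a range from 800 nM to 4000 nM.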

Compound 4, half-maximal inhibitory concentration: 1040 nM
Beside the measured number, compound 4's estimate is 1.7-fold (0.24 log units) above it; measured number inside the range.
By their numbers in this assay, from the lowest: compounds 4, 3, 2 and 1 (each within the scatter of the next, the first and the last beyond it).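

In this assay, this exchange of one halogen for another at the same ring position gives a 1.9-fold lower number from compound 3 to compound 4 (0.29 log units; within the scatter), so the 3-chlorophenyl and 3-bromophenyl compounds cannot be told apart on this evidence. Among these compounds, the new information lies in the wider comparison: replacing 4-isopropylphenyl with 3-bromophenyl gives a 2.4-fold lower number from compound 2 to compound 4 (0.38 log units; beyond the scatter), a gap beyond the scatter that the chloro compound did not show against compound 2, while replacing 4-methoxyphenyl with 3-bromophenyl gives a 4.5-fold lower number from compound 1 to compound 4 (0.65 log units; beyond the scatter), the widest step so far, though still a modest one. Nothing measured here explains why these numbers fall as they do.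

The compounds shown leave open whether the trend continues along the halogens, since a fluoro or iodo group at this position would be needed to test it, and whether a group of a different kind, such as a nitrile, an amine or a carboxylic acid, would be accepted there. They also leave open whether a phenyl ring with no added group would stand near the halogen compounds or near compound 1.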